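Rearranging the fluoro-nitrophenyl group on a sulfonyl sulfur

This account rests on a few compounds, and the source may have more. Where it says the series, first, only, none or still open, it means among the compounds named here.

Three compounds have been measured in a functional assay on K562 cells (Homo sapiens) for inhibition, read by trypan blue exclusion, with a stated time of 72 h (a higher number here means a weaker inhibitor, a lower number a stronger inhibitor), for their half-maximal inhibitory concentration:

Compound 1 (`Cn1c(=O)c(S(=O)(=O)c2ccc(C(=O)O)cc2)cc2cnc(Nc3ccc4[nH]ccc4c3)nc21`) gives 5000 nM
Compound 2 (`Cn1c(=O)c(S(=O)(=O)Nc2ccc(F)cc2)cc2cnc(Nc3ccc4[nH]ccc4c3)nc21`) gives 5000 nM
Compound 3 (`Cn1c(=O)c(S(=O)(=O)c2ccc(F)cc2[N+](=O)[O-])cc2cnc(Nc3ccc4[nH]ccc4c3)nc21`) gives 900 nM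

Compound 3 has the lowest number of the three, and both other compounds lie above it by more than the scatter. Compound 4 (`Cn1c(=O)c(S(=O)(=O)c2ccc([N+](=O)[O-])cc2F)cc2cnc(Nc3ccc4[nH]ccc4c3)nc21`) has the same atoms as compound 3, joined differently. The change is 2-fluoro-4-nitrophenyl in place of 4-fluoro-2-nitrophenyl on a sulfonyl sulfur and it places 2-fluoro-4-nitrophenyl in place of 4-fluoro-2-nitrophenyl on a sulfonyl sulfur.

Two measured steps at this place bear on it, a 5.6-fold lower number from compound 1 to compound 3 (0.74 log units; beyond the scatter) and a 5.6-fold lower number from compound 2 to compound 3 (0.74 log units; beyond the scatter) and both are modest. A third, no change at the digits printed from compound 1 to compound 2 (within the scatter) and so within the scatter, shows that not every exchange here moves the number. For the measured compounds named here, no measured pair isolates a swap of these two groups on the ring. A small rise is expected, possibly none beyond the scatter, as compound 3 at 900 nM is the lowest so far.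

The expected step is a 1.7-fold higher number from compound 3 to compound 4 (0.22 log units; within the scatter) as an estimate only. For compound 4 the estimated value is 1500 nM with 500 nM to 4500 nM as the expected range.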

Compound 4, half-maximal inhibitory concentration: 200 nM
Compound 4: middle estimate off by 7.5-fold (0.88 log units), on the high side; measured number outside the range, below it.
By their numbers in this assay, from the lowest: compound 4; then compound 3; then compounds 1 and 2 (each within the scatter of the next).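

In this assay, exchanging 4-fluoro-2-nitrophenyl for 2-fluoro-4-nitrophenyl gives a 4.5-fold lower number from compound 3 to compound 4 (0.65 log units; beyond the scatter), so at this place the arrangement of the same atoms moves the number beyond the scatter, something that compound 1, compound 2 and compound 3 could not show. For the compounds shown here, the two other new comparisons are large, a 25-fold lower number from compound 2 to compound 4 (1.40 log units; beyond the scatter) and a 25-fold lower number from compound 1 to compound 4 (1.40 log units; beyond the scatter), whereas the earlier steps at this place were modest or within the scatter. Nothing available explains why this rearrangement changes the number.

On these data alone, it remains open whether an amine or a nitrile in place of the nitro group of 2-fluoro-4-nitrophenyl would keep the number of compound 4. It is equally open whether the fluorine is needed at all, as no plain nitrophenyl group on the sulfonyl sulfur appears among these compounds.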